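Benzyl to 4-Methoxyphenyl on the Shared Core: Expected Acid Dissociation

The source may hold more compounds than are shown below. What is called first, only, known or untested is meant among the compounds shown, and "the series" means these compounds.

Three compounds have been measured so far:
compound 1, `COc1ccc(Oc2ccc3c(NCCCNCc4cc(F)ccc4OC)ccnc3c2)cc1`, 9.28
compound 2, `COc1cccc(CNCCCNc2ccnc3cc(Cc4ccccc4)ccc23)c1O`, 9.47
compound 3, `COc1ccc(F)cc1CNCCCNc1ccnc2cc(Cc3ccccc3)ccc12`, 9.47

In a physicochemical assay for acid dissociation, compound 2 gives 9.47. It sits level with compound 3 at the digits printed, and the two together are the highest of the three numbers; the nearest neighbour is compound 3, with no change at the digits printed from compound 2 to compound 3 (within the scatter), and the furthest is compound 1, which gives 9.28. The gap from compound 1 to compound 3 is also small, a number 0.19 log units higher from compound 1 to compound 3 (within the scatter).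

Compound 4, `COc1ccc(-c2ccc3c(NCCCNCc4cccc(OC)c4O)ccnc3c2)cc1`, differs from compound 2 in one place:
4-methoxyphenyl in place of benzyl on an aromatic carbon

The step that bears on this change is the one at the same aromatic carbon, where a benzyl replaced a 4-methoxyphenoxy, a number 0.19 log units higher from compound 1 to compound 3 (within the scatter). The other step, from compound 2 to compound 3, altered the aryl on the saturated chain instead and was no change at the digits printed from compound 2 to compound 3 (within the scatter). Neither change to the outer groups of the shared core moved the number beyond the scatter, so no step beyond the scatter is expected here either. Compound 4 is therefore expected to give 9.45, within 9.15 to 9.75, which means an expected step of a number 0.02 log units lower from compound 2 to compound 4 (within the scatter).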

Compound 4, acid dissociation constant: 9.47
Compound 4: middle estimate off by 0.02 log units, on the low side; the measured number falls inside the stated range.
By their numbers in this assay, from the lowest: compounds 1, 2, 3 and 4 (each within the scatter of the next).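

At this aromatic carbon, 4-methoxyphenyl in place of benzyl gives, in this assay, no change at the digits printed from compound 2 to compound 4 (within the scatter), even though the entering group adds an oxygen and a hydrogen-bond acceptor. The earlier step at this carbon, benzyl in place of 4-methoxyphenoxy, was read only in the pair carrying the 5-fluoro-2-methoxyphenyl group, as a number 0.19 log units higher from compound 1 to compound 3 (within the scatter); the new step extends the reading to a pair carrying the 2-hydroxy-3-methoxyphenyl group and to an aryl ring bound directly to the core, and it too stays within the scatter. Nothing shown gives a measured reason why the number holds at this position.

On these data alone, all the groups seen at this aromatic carbon carry a six-membered aromatic ring of carbon only, so it remains open whether a group without such a ring, such as a carboxylic acid or a dimethylamino group, would move the number beyond the scatter. As far as these compounds go, it also remains open whether 4-methoxyphenyl would give the same reading in a compound carrying the 5-fluoro-2-methoxyphenyl group on the chain.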